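The source may hold more compounds than are shown below. What is called first, only, known or untested is meant among the compounds shown, and "the series" means these compounds.

Within the data shown here, only two compounds have numbers so far. In an ADME assay on a cell-free system (plasma, Rattus norvegicus) for protein binding, compound 2 (`Cc1ccc(-c2cc(C(=O)N[C@H](C)c3ccc(F)cn3)cc(C(C)(C)O)c2)nc1`) gives 82% as its reading, and compound 1 (`Cc1ccc(-c2cc(C(=O)N[C@@H](C)c3nnc[nH]3)cc(-c3ncccc3F)c2)nc1`) gives 98.8% as its reading. Compound 2 therefore has the larger unbound fraction of the pair, and the gap between the two lies beyond the scatter. These two compounds differ in more than one place, so no single change has yet been measured on its own.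

Compound 3 (`Cc1ccc(-c2cc(C(=O)N[C@H](C)c3ccc(F)cn3)cc(-c3ncccc3F)c2)nc1`) departs from compound 2 in one place only. The change is 3-fluoropyridin-2-yl in place of 1-hydroxy-1-methylethyl on an aromatic carbon and it puts 3-fluoropyridin-2-yl in place of 1-hydroxy-1-methylethyl on an aromatic carbon, meta to a 5-methylpyridin-2-yl group.

Among the measured compounds shown here, the only guide is compound 1, which already carries the 3-fluoropyridin-2-yl group and reads 98.8% in this assay despite its different amide side. On that single comparison, more binding is expected. The expected step a 7.2-fold lower unbound fraction from compound 2 to compound 3 (0.86 log units; beyond the scatter) points towards a smaller free share and is estimated to lie beyond the scatter. In this assay compound 3 is estimated at 97.5% within a range of 93% to 99.4% as its expected reading.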

Compound 3, plasma protein binding: 99.2%
Beside the measured number, compound 3's estimate is 3.1-fold (0.49 log units) (unbound fraction) above it; the measured number falls inside the stated range.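

In this assay, among these compounds, 3-fluoropyridin-2-yl in place of 1-hydroxy-1-methylethyl on this aromatic carbon is the first change that can be read on its own, and it amounts to a 23-fold lower unbound fraction from compound 2 to compound 3 (1.35 log units; beyond the scatter). The second single change, 1-(5-fluoropyridin-2-yl)ethyl in place of 1-(4H-1,2,4-triazol-3-yl)ethyl on an amide-type nitrogen, gives a 1.5-fold lower unbound fraction from compound 1 to compound 3 (0.18 log units; within the scatter), so with 3-fluoropyridin-2-yl present, the swap on the amide side cannot be told apart from the scatter, while the change at the position meta to the 5-methylpyridin-2-yl group clearly can. No measurement at hand accounts for the size of the step at this position.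

The compounds shown place only two groups at this position, so they leave open how an amine, a carboxylic acid or a pyridin-2-yl ring without fluorine would read there. They also leave open whether the 1-(4H-1,2,4-triazol-3-yl)ethyl side would stay as close to the 1-(5-fluoropyridin-2-yl)ethyl side if 1-hydroxy-1-methylethyl sat on the aromatic carbon instead of 3-fluoropyridin-2-yl.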